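The source may report more compounds than this note shows. Statements on the series, on what has been measured and on what is new or still open speak of the compounds shown alone.

Two compounds of this series carry numbers in a functional assay on cells for antagonist activity at Neuropeptide Y receptor type 5 (Homo sapiens); a higher number here means a weaker inhibitor, a lower number a stronger inhibitor. Compound 1 `c1ccc(Nc2nc(NC3CCCCC3)nc3ccccc23)cc1` gives 50 nM in this assay. Compound 2 `CN(C[C@H]1CC[C@H](CN(C)S(=O)(=O)c2cccc3ccccc23)CC1)c1nc(N)c2ccccc2n1` gives 710 nM, the higher of the two numbers; its nearest neighbour is compound 1, and the gap between them lies beyond the scatter. For the measured compounds named here, no pair of measured compounds differing in a single place is available, so no measured step can be read from the set.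

Compound 3 `CN(C[C@H]1CC[C@H](CNS(=O)(=O)c2cccc3ccccc23)CC1)c1nc(N)c2ccccc2n1` has not yet been measured in this assay. It differs from compound 2 by hydrogen in place of methyl on a sulfonamide nitrogen. Without a measured step of this kind, the expectation rests on compound 2 alone, whose value of 710 nM is the starting point, and a change this small in count is expected to give a step of a 1.2-fold lower number from compound 2 to compound 3 (0.07 log units; within the scatter), not beyond the scatter. Compound 3 is expected to give about 600 nM, within a range of 250 nM to 1500 nM.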

Compound 3, half-maximal inhibitory concentration: 16 nM
Estimate against measurement, compound 3: 38-fold (1.57 log units) above; the whole stated range lies above it.
By their numbers in this assay, from the lowest: compound 3; then compound 1; then compound 2.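

In this assay, for the compounds shown here, hydrogen in place of methyl on the sulfonamide nitrogen gives a 44-fold lower number from compound 2 to compound 3 (1.65 log units; beyond the scatter), the first measured step and one that lies well beyond the scatter. Going by these compounds alone, the sulfonamide nitrogen is therefore a position where the loss of one heavy atom, a single carbon, with no ring and no net charge involved, is enough to produce a large change in this pair, something the earlier compounds, which differ in more than one place, could not show. The data at hand offer nothing that accounts for the size of this step.

The compounds shown leave open whether an ethyl group, a longer chain or a hydroxyethyl chain on this nitrogen would fall nearer to the methyl or the hydrogen compound. This one pair also leaves open whether a step of this size would recur with the naphthalene sulfonyl group replaced by a phenyl sulfonyl group.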